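Removing the methyl on a second core: what to expect

A few compounds are considered here, and "the series" means these few. Any claim that something is new, unique, unknown or untested is made for them only; others in the source may bear on it.

The study measures growth inhibition in a functional assay on PC-3 cells (Homo sapiens); on this read-out lower numbers stand for stronger inhibition of growth and higher numbers for weaker inhibition of growth. Compound 2 `Cc1ccnc2nc(-c3ccc(Cl)cc3)cc(O)c12` gives 2880 nM in this assay, and compound 1 `Oc1cc(-c2ccc(Cl)cc2)nc2ncccc12` gives 47900 nM. The change between them, (hydrogen in place of methyl on an aromatic carbon), brought a 17-fold higher number from compound 2 to compound 1 (1.22 log units; beyond the scatter).

Compound 3 `COc1ccccc1-c1cc(O)c2ccc(C)nc2n1` has a different core; the difference between the two cores is not broken down here. In this assay compound 3 reaches only a limit, > 100000 nM, one of the values at the limit of > 100000 nM in this assay, at which 1 of the 3 values shown sits.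

Compound 4 `COc1ccccc1-c1cc(O)c2cccnc2n1` stands to compound 3 as compound 1 stands to compound 2: hydrogen in place of methyl on an aromatic carbon. The surroundings differ, however. In compound 2 the methyl sits ortho to a fused ring, meta to a fused ring, opposite the ring nitrogen; in compound 3 it sits next to the ring nitrogen, meta to a fused ring, para to a fused ring. It is therefore the same kind of change, not the same change.

The expectation for compound 4 starts from the limit of compound 3, > 100000 nM. It also draws on the step of a 17-fold higher number from compound 2 to compound 1 (1.22 log units; beyond the scatter), which weakened inhibition. Compound 4 is accordingly expected to give about 300000 nM, between 100000 nM and 1500000 nM. The expected step is a step that the limit leaves unreadable from compound 3 to compound 4, most likely reported again as a limit.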

Compound 4, concentration for 50% growth inhibition: 29500 nM
Compound 4: the middle estimate sits 10-fold (1.01 log units) above what was measured, and the stated range ends above it.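

In this assay, hydrogen in place of methyl on an aromatic carbon brought an at least 3.3-fold lower number from compound 3 to compound 4 (0.53 log units; beyond the scatter), so the change did not keep its direction when carried from one core to the other: the same change on two cores in this assay, a 17-fold higher number (1.22 log units; beyond the scatter) from compound 2 to compound 1 and an at least 3.3-fold lower number (0.53 log units; beyond the scatter) from compound 3 to compound 4, at least 56-fold (1.75 log units) apart, beyond the scatter of two such steps. The full size of the new step cannot be read, as compound 3 stands at a limit of the assay: the limit of > 100000 nM in this assay, at which 1 of the 4 values shown sits. The two pairs show that the effect seen on one core cannot be assumed on the other, but they do not show what sets the difference, since the place of the methyl and the rest of the structure vary together between them, and two pairs make no rule for the series.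

The compounds shown leave open whether the place of the methyl alone, with the rest of the structure held constant, would reverse the step. They also leave open how an ethyl group or an amine in place of the methyl would behave on either core.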